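The source may hold more compounds than are shown below. What is called first, only, known or untested is meant among the compounds shown, and "the series" means these compounds.

Working notes on the tetrabrominated series. Two members have been run so far in a functional assay on MCF7 cells (Homo sapiens) for antiproliferative activity, read by MTT assay, with a stated time of 48 h, tested at 100 uM; a lower number here means a stronger effect, a higher number a weaker effect of the compound at the concentration tested. Compound 1 `OC(CCn1nc2c(Br)c(Br)c(Br)c(Br)c2n1)c1ccc(Br)cc1` gives 0% in this assay. Compound 2 `C[C@@H](O)CCn1nc2c(Br)c(Br)c(Br)c(Br)c2n1` gives 0% in this assay, level with compound 1 at the digits reported, so no change between the two is seen within the scatter. Among the measured compounds shown here, no step between two measured compounds differing in a single place is available, so nothing can be said about the weight of any one change from the measured pairs.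

Compound 3 `CC(O)CCn1nc2c(Br)c(Br)c(Br)c(Br)c2n1` is the next member to go into this assay. The change from compound 2 is the two compounds have the same atoms and bonds; at least one stereo element is drawn with a configuration in one of them and without one in the other: 1 of 1 stereo elements differ; a stereocentre at a saturated chain carbon is drawn R in compound 2 and without a configuration in compound 3. The atoms and bonds are the same; only the stereocentre at the saturated chain carbon, drawn R in compound 2, is drawn without a configuration in compound 3. A step of no size beyond the scatter is expected from this change, given that compound 2 sits at 0%. Compound 3 is therefore expected to read 0% in this assay, with a range of 0% to 10%, the expected step of no change at the digits printed from compound 2 to compound 3 (within the scatter) lying within the scatter.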

Compound 3, a percentage reported as activity, at one concentration (the size of the read-out at that concentration, not a potency): 0%
Compound 3: the middle estimate sits on the measured number at the digits printed; the measured number falls inside the stated range.
By their numbers in this assay, from the lowest: compounds 1, 2 and 3 (each within the scatter of the next).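

In this assay the series now has its first steps that differ in one place. Removing the drawn configuration at the saturated chain carbon gives no change at the digits printed from compound 2 to compound 3 (within the scatter), so the R drawing in compound 2 carries no readable weight in this read-out, and the pair is separated only by this: the fact that one of compounds 2 and 3 is drawn with a defined configuration and the other without, at the place where they differ. Methyl in place of 4-bromophenyl at that same carbon gives no change at the digits printed from compound 1 to compound 3 (within the scatter), so even this exchange of substituents leaves no readable mark on the shared core at the concentration tested.

Open, on these data alone, is whether an amine or a carboxylic acid in place of the hydroxyl, or a longer chain, would read apart from these three compounds. Also open, as far as these compounds go, is whether a compound drawn with the opposite configuration at that carbon would do so.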